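A few compounds are considered here, and "the series" means these few. Any claim that something is new, unique, unknown or untested is made for them only; others in the source may bear on it.

In an ADME assay on THP-1 cells (Homo sapiens) for cytotoxicity (on this read-out lower numbers stand for higher toxicity in this test and higher numbers for lower toxicity in this test), compound 2 `COc1ccc(CNC(=O)c2c(NC(=O)C(F)(F)F)sc3c2CCCCC3)cc1` gives > 50000 nM, which is a limit of the assay and not a number. Compound 1 `N#Cc1ccc(NC(=O)c2c(NC(=O)C(F)(F)F)sc3c2CCCCC3)cc1` gives 9110 nM. Compound 3 `COc1cccc(NC(=O)c2c(NC(=O)C(F)(F)F)sc3c2CCCCC3)c1` differs from compound 2 on the amide-type nitrogen: 3-methoxyphenyl in place of 4-methoxybenzyl on an amide-type nitrogen. Within the data shown here, the one measured step that bears on this is an at least 5.4-fold higher number from compound 1 to compound 2 (0.73 log units; beyond the scatter), which ended in the same 4-methoxybenzyl. Compound 3 instead carries a substituted phenyl there, as compound 1 does, so a modest step the opposite way, toward a lower number and higher toxicity, is expected. The expected change is an at least 3.1-fold lower number from compound 2 to compound 3 (0.49 log units; beyond the scatter). For compound 3 the estimated value is 16000 nM, with an expected range of 6000 nM to 45000 nM.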

Compound 3, half-maximal cytotoxic concentration: 37600 nM
The estimate for compound 3 lay 2.4-fold (0.37 log units) below the measured number; the measured number falls inside the stated range.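

In this assay, a substituted phenyl on the amide-type nitrogen does not by itself bring the number down to that of compound 1, as the 3-methoxyphenyl shows with a 4.1-fold higher number from compound 1 to compound 3 (0.62 log units; beyond the scatter). The step from the 4-methoxybenzyl reads an at least 1.3-fold lower number from compound 2 to compound 3 (0.12 log units; that floor lies within the scatter), and that floor lies within the scatter, so no drop is established. Compound 2 carries a limit of the assay, not a number: the limit of > 50000 nM in this assay, at which 1 of the 3 values shown sits.

Still open, from the compounds shown here alone, is whether the nitrile or its ring position sets compound 1 apart. A 3-cyanophenyl or 4-methoxyphenyl on this nitrogen would separate the two.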